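Notes on the series: compound 2 to compound 3

This account rests on a few compounds, and the source may have more. Where it says the series, first, only, none or still open, it means among the compounds named here.

- Compound 1 `Cc1cc(C(=O)N2CCC3(CC2)CC(=O)N(c2ccc(C(F)(F)F)cc2)C3)cc2cn[nH]c12`: > 10000 nM (a limit, not a number)
- Compound 2 `O=C(c1ccc2[nH]c(-c3ccccc3)nc2c1)N1CCC2(CC1)CC(=O)N(c1ccc(C(F)(F)F)cc1)C2`: 5420 nM

Both entries come from a functional assay on Caco-2 cells (Homo sapiens) for antiproliferative activity, read by MTT assay, with a stated time of 48 h; a lower number here means a stronger inhibitor, a higher number a weaker inhibitor. Within the data shown here, compound 2, at 5420 nM, holds the only numeric value so far. Compound 1 reaches only a limit of the assay, > 10000 nM.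

Compound 3 `CC(C)c1ccc(-c2nc3cc(C(=O)N4CCC5(CC4)CC(=O)N(c4ccc(C(F)(F)F)cc4)C5)ccc3[nH]2)cc1` differs from compound 2 by isopropyl in place of hydrogen on an aromatic carbon, or phenyl to 4-isopropylphenyl. Among the measured compounds shown here, no measured pair shows a change of this kind, so the expectation is loose and stays anchored on compound 2 at 5420 nM. A small shift toward stronger inhibition is expected in this assay, not clearly beyond the usual scatter. The expected change is a 1.4-fold lower number from compound 2 to compound 3 (0.13 log units; within the scatter). Compound 3 is estimated at 4000 nM, with an expected range of 1500 nM to 10000 nM.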

Compound 3, half-maximal inhibitory concentration: > 10000 nM
Compound 3: no number, only a limit (the forecaster's own chance of this, stated with the estimate: 15%); middle value at least 2.5-fold (0.39 log units) away from the limit.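

In this assay, isopropyl in place of hydrogen on an aromatic carbon, para to a large group, gives an at least 1.8-fold higher number from compound 2 to compound 3 (0.26 log units; that floor lies within the scatter). Compound 3 gives > 10000 nM, which is a limit of the assay and not a number, so this first change at the position brings no sign of stronger inhibition, and it is not shown to weaken inhibition beyond the scatter. The step can be read no further than its floor: the limit of > 10000 nM in this assay, at which 2 of the 3 values shown sit.

Going by these compounds, how far compound 3 truly lies from compound 2 stays open. Also open, on these data alone, is whether the outcome belongs to isopropyl alone or to any replacement of hydrogen at this place, a question that a methoxy group, an amine or a carboxylic acid there would address.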